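Removing the Ring Nitrogen Methyl on a Pyridinol Core

The compounds below may be only part of what the source reports. "The series", "measured", "known", "first", "only" and "open" are said of these compounds alone.

Compound 1 `CN1CCC[C@H]1COc1cncc(O)c1` stands lowest of the three compounds examined in an assay on HEK293 cells for displacement of a labelled ligand from Neuronal acetylcholine receptor; alpha3/beta4 (Homo sapiens), read by scintillation counting (on this read-out higher numbers stand for weaker inhibition and lower numbers for stronger inhibition), where compound 1 gives 235 nM. Compound 3 `COc1ncccc1OC[C@@H]1CCCN1C` shares a pyrrolidine-linked arrangement but differs in its aromatic portion; the difference between the two cores is not broken down here. In this assay compound 3 gives 793 nM. Compound 2 `COc1ncccc1OC[C@@H]1CCCN1` carries the same core as compound 3 but with a hydrogen on the ring amine; in this assay compound 2 gives 5300 nM.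

Between compound 3 and compound 2 the change is hydrogen in place of methyl on an amine nitrogen in a ring. This produced a 6.7-fold higher number from compound 3 to compound 2 (0.83 log units; beyond the scatter).

Compound 4 `Oc1cncc(OC[C@@H]2CCCN2)c1` has not yet been measured. It relates to compound 1 through (hydrogen in place of methyl on an amine nitrogen in a ring). Among the measured compounds shown here, this is the same kind of change as the one from compound 3 to compound 2, though the surroundings are described a little differently: in compound 1 the amine nitrogen sits next to the ring atom that bears a group of 9 heavy atoms, while in compound 3 it sits next to the ring atom that bears a large group.

Because the same kind of change gave a 6.7-fold higher number from compound 3 to compound 2 (0.83 log units; beyond the scatter), compound 4 is expected to show a step of about a 6.4-fold higher number from compound 1 to compound 4 (0.81 log units; beyond the scatter) in this assay, with the expectation resting only on that single precedent. Compound 4 is therefore estimated at 1500 nM, with a likely range from 500 nM to 4500 nM.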

Compound 4, inhibition constant: 100 nM
Compound 4: middle estimate off by 15-fold (1.18 log units), on the high side, outside the stated range (below it).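

In this assay, hydrogen in place of methyl on an amine nitrogen in a ring gave a 2.4-fold lower number from compound 1 to compound 4 (0.37 log units; beyond the scatter), a modest step that runs the opposite way to the one seen on the other core. Set beside that earlier step, the change does not carry over from one core to the other in this series, not even in its direction: the same change on two cores in this assay, a 6.7-fold higher number (0.83 log units; beyond the scatter) from compound 3 to compound 2 and a 2.4-fold lower number (0.37 log units; beyond the scatter) from compound 1 to compound 4, 16-fold (1.20 log units) apart, beyond the scatter of two such steps This shows that the effect of removing the methyl depends on the core that carries it, but it rests on only two matched pairs, so it does not show which difference between the cores matters, or which of the two steps would be more typical on a further core.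

The compounds shown leave open how an ethyl group or a longer chain on the same amine nitrogen would read on either core. They also leave open which feature of the aromatic portion separates the two outcomes, as no pair shown changes that portion alone, with the methyl or the hydrogen on the amine nitrogen held fixed.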